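A Methyl Added to the Chain of Compound 2

The source may report more compounds than this note shows. Statements on the series, on what has been measured and on what is new or still open speak of the compounds shown alone.

Compound 2 `CCC(C)(C)/N=C(\NC#N)Nc1cc(Cl)cc(C#N)c1` was tested in a functional assay (trachea) with Cavia porcellus as the target (on this read-out lower numbers stand for an effect already at smaller amounts and higher numbers for an effect only at larger amounts of compound), where compound 2 gives 0.28 uM. Among the three compounds measured, compound 2 stands second highest. Compound 3 `CCC(C)(C)/N=C(\NC#N)Nc1cc(Br)cc(C#N)c1` gives 0.08 uM in this assay, and the single-place change between them yields a 3.5-fold lower number from compound 2 to compound 3 (0.54 log units; beyond the scatter). Within the data shown here, compound 1 `CCC(CC)(CC)/N=C(\NC#N)Nc1cc(Cl)cc(Cl)c1` gives 30 uM in this assay; compound 1 differs from compound 2 in more than one place, so no single step is drawn from it.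

The new compound 4 `CC(C)C(C)(C)/N=C(\NC#N)Nc1cc(Cl)cc(C#N)c1` differs from compound 2 by methyl in place of hydrogen on a saturated chain carbon bound to two saturated chain carbons. Among the measured compounds shown here, no measured step concerns this part of the molecule: the only single-place step, that of bromo in place of chloro on an aromatic carbon, touches the ring, and compound 1 differs in several places at once. With nothing to point a direction, compound 4 is expected to differ by a 1.1-fold higher number from compound 2 to compound 4 (0.03 log units; within the scatter), a step not beyond the usual scatter. The estimate for compound 4 in this assay is 0.3 uM, within a range from 0.1 uM to 1 uM.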

Compound 4, concentration for half-maximal effect: 0.69 uM
Compound 4: middle estimate off by 2.3-fold (0.36 log units), on the low side, within the range that was stated.
By their numbers in this assay, from the lowest: compound 3; then compound 2; then compound 4; then compound 1.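

Adding a methyl to the saturated chain carbon, which turns the 1,1-dimethylpropyl group of compound 2 into 1,1,2-trimethylpropyl, gives a 2.5-fold higher number from compound 2 to compound 4 (0.39 log units; beyond the scatter) in this assay. Among these compounds, this is the first single-place step read on the chain rather than on the ring, and it shows that this part of the molecule is not silent: a change as small as a methyl for a hydrogen moves the number beyond the usual scatter. The step is modest, and here it means that more compound is needed for the same effect.

As far as these compounds go, whether a hydroxyl group or a longer chain such as propyl at this carbon would move the number the same way remains open. So does whether the methyl would act alike on the bromo ring of compound 3. What lies behind the rise in the number finds no support in any measurement at hand.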